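Removing one acetyl from compound 2

A few compounds are considered here, and "the series" means these few. Any claim that something is new, unique, unknown or untested is made for them only; others in the source may bear on it.

The series rests on compound 1 `CCCCCCCCO[C@@H]1O[C@@H](C)[C@H](OC(=O)CCCCC)[C@@H](O[C@@H]2O[C@@H](C)[C@H](OC(C)=O)[C@@H](O)[C@H]2OC(C)=O)[C@H]1O` and compound 2 `CCCCCCCCO[C@@H]1O[C@@H](C)[C@H](OC(=O)CCCCC)[C@@H](O[C@@H]2O[C@@H](C)[C@H](OC(C)=O)[C@@H](OC(C)=O)[C@H]2OC(C)=O)[C@H]1O`. In a functional assay on LNCaP cells (Homo sapiens) for cytotoxicity (on this read-out higher numbers stand for an effect only at larger amounts of compound and lower numbers for an effect already at smaller amounts), compound 1 gives > 20 ug/mL, which is a limit of the assay rather than a number. In this assay compound 2 likewise gives > 20 ug/mL, again only a limit. The step that the two limits leave unreadable from compound 1 to compound 2 therefore cannot be read, since both ends sit at the limit of > 20 ug/mL in this assay, at which 2 of the 2 values shown sit. Compound 2 thus stands at the limit, and no number below it has been seen for it.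

Compound 3 `CCCCCCCCO[C@@H]1O[C@@H](C)[C@H](OC(=O)CCCCC)[C@@H](O[C@@H]2O[C@@H](C)[C@H](O)[C@@H](OC(C)=O)[C@H]2OC(C)=O)[C@H]1O` differs from compound 2 by hydrogen in place of acetyl on an oxygen on a saturated carbon. Within the data shown here, the only measured step, the one from compound 1 to compound 2, also concerns acetyl on an oxygen on a saturated carbon, and its size is not readable; it shows no movement away from the limit. Among the measured compounds shown here, no measured step gives a size for the change to compound 3. The step expected from this, a step that the limit leaves unreadable from compound 2 to compound 3, is estimated to stay within the scatter. Compound 3 is estimated at 30 ug/mL, with a range from 12 ug/mL to 80 ug/mL.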

Compound 3, concentration for half-maximal effect: > 20 ug/mL
Compound 3: only a limit was reported; the forecaster's own chance of this, stated with the estimate: 80%; the middle value does not contradict the limit.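

In this assay compound 3 gives > 20 ug/mL, a limit and not a number. Compound 2 sits at the same limit, so no step can be read between compound 2 and compound 3: the limit of > 20 ug/mL in this assay, at which 3 of the 3 values shown sit. The compounds shown leave open how large either acetyl change is in this assay, and which structure, if any, gives a number there rather than a limit.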